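Bromo for ethynyl: a thiourea sulfonamide pair

This account rests on a few compounds, and the source may have more. Where it says the series, first, only, none or still open, it means among the compounds named here.

compound 1 `COc1cc2ncnc(Nc3cccc(Br)c3)c2cc1OCCCCC(=O)Nc1ccc(S(N)(=O)=O)cc1` 11400 nM
compound 2 `C#Cc1cccc(Nc2ncnc3ccc(NC(=S)Nc4ccc(S(N)(=O)=O)cc4)cc23)c1` 13400 nM

In a functional assay on NCI-H1975 cells (Homo sapiens) for antiproliferative activity, read by MTT assay, with a stated time of 72 h (a higher number here means a weaker inhibitor, a lower number a stronger inhibitor), compound 1 gives 11400 nM and compound 2 gives 13400 nM. The two numbers lie within the usual scatter of one another, so compound 2 cannot be set apart from compound 1 on these figures. Compound 3 `NS(=O)(=O)c1ccc(NC(=S)Nc2ccc3ncnc(Nc4cccc(Br)c4)c3c2)cc1` is not yet measured. It differs from compound 2 by bromo in place of ethynyl on an aromatic carbon. For the measured compounds named here, no step between measured compounds covers this change, so nothing points to a direction. The expected step from compound 2 to compound 3 is a 1.0-fold higher number from compound 2 to compound 3 (0.02 log units; within the scatter), none beyond the scatter. Compound 3 is estimated at 14000 nM, in a range from 5000 nM to 40000 nM.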

Compound 3, half-maximal inhibitory concentration: 11000 nM
Compound 3: the middle estimate sits 1.3-fold (0.10 log units) above what was measured; low and high end bracket the measured number.
By their numbers in this assay, from the lowest: compounds 3, 1 and 2 (each within the scatter of the next).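

Notes on the group meta to the large group: in this assay this pair gives the first reading of the change, with bromo in place of ethynyl giving a 1.2-fold lower number from compound 2 to compound 3 (0.09 log units; within the scatter), so compound 2 and compound 3 cannot be told apart. On this thiourea sulfonamide scaffold, 3-ethynylphenyl and 3-bromophenyl read alike. No measurement offers an explanation for this.

As far as these compounds go, whether an amine, a carboxylic acid or a longer chain at this position would read apart from bromo and ethynyl remains open. So does whether the two groups also read alike with another linker.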